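The source may report more compounds than this note shows. Statements on the series, on what has been measured and on what is new or still open speak of the compounds shown alone.

In a functional assay on HeLa cells (Homo sapiens) for cytotoxicity, with a stated time of 72 h (a lower number here means a stronger inhibitor, a higher number a weaker inhibitor), compound 2 `Clc1ccc(Cc2nn3cc(-c4ccccc4)nc3s2)cc1` gives only a limit of the assay, > 250000 nM. Compound 1 `Fc1ccc(-c2cn3nc(Cc4ccc(Cl)cc4)sc3n2)cc1` carries fluoro where compound 2 carries hydrogen. In this assay compound 1 also gives only a limit, > 250000 nM. Compound 3 `O=[N+]([O-])c1ccc(-c2cn3nc(Cc4ccc(Cl)cc4)sc3n2)cc1`, with nitro in place of hydrogen on an aromatic carbon, likewise gives only a limit, > 250000 nM. The steps among these three, a step that the two limits leave unreadable from compound 1 to compound 2, a step that the two limits leave unreadable from compound 1 to compound 3 and a step that the two limits leave unreadable from compound 2 to compound 3, cannot be sized because of the limit of > 250000 nM in this assay, at which 3 of the 3 values shown sit. Compound 4 `N#CSc1c(-c2ccccc2)nc2sc(Cc3ccc(Cl)cc3)nn12` differs from compound 2 by cyanosulfanyl in place of hydrogen on an aromatic carbon on the shared core. Among the measured compounds shown here, no measured step bears directly on this change; the three measured compounds show only that exchanging fluoro, hydrogen and nitro on an aromatic carbon left every value at the limit. Compound 4 is therefore expected to remain weak, and the step of an at least 1.6-fold lower number from compound 2 to compound 4 (0.22 log units; that floor lies within the scatter) is expected to be small. The estimate for compound 4 in this assay is 150000 nM, between 30000 nM and 250000 nM.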

Compound 4, half-maximal inhibitory concentration: 12000 nM
Beside the measured number, compound 4's estimate is 13-fold (1.10 log units) above it; the measured number lies below the stated range.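

In this assay, compound 4 gives 12000 nM, the first readable number among the compounds shown. That is an at least 20-fold lower number from compound 2 to compound 4 (1.31 log units; beyond the scatter), so cyanosulfanyl on this carbon of the five-membered ring moves the number clear of the limit, which the fluoro and nitro exchanges on the phenyl group did not do. The full size of this step remains unknown, and the steps among compound 1, compound 2 and compound 3 cannot be read: the limit of > 250000 nM in this assay, at which 3 of the 4 values shown sit.

The compounds shown leave open whether the sulfur or the nitrile within cyanosulfanyl matters more for this step, or whether both are needed. A methylsulfanyl group or a lone nitrile on the same carbon would separate the two, and an amine there would test whether a quite different group also lowers the number.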